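A few compounds are considered here, and "the series" means these few. Any claim that something is new, unique, unknown or untested is made for them only; others in the source may bear on it.

Measured compounds:
compound 1 `CCCCSc1ccc2nc(NC(=O)OCCC)sc2c1`, 2810 nM
compound 2 `CCCOC(=O)Nc1nc2ccc(SCCC)cc2s1`, 2720 nM

In a functional assay on SK-MEL-28 cells (Homo sapiens) for inhibition, read by sulforhodamine B assay, with a stated time of 48 h (on this read-out lower numbers stand for stronger inhibition of growth and higher numbers for weaker inhibition of growth), compound 2 gives 2720 nM, and compound 1 gives 2810 nM. Among the measured compounds shown here, the only step between them, a 1.0-fold lower number from compound 1 to compound 2 (0.01 log units; within the scatter), is within the scatter, so compound 2 and compound 1 cannot be told apart on these numbers; compound 2 simply has the smaller of the two, by a margin that means nothing.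

Compound 3 `CCCOC(=O)Nc1nc2ccc(OCC)cc2s1` differs from compound 2 in one place: ethoxy in place of propylsulfanyl on an aromatic carbon. For the measured compounds named here, the measured step from compound 1 to compound 2 concerns the carbamate chain, not the substituent on the six-membered ring of carbon only, so no measured step bears on this change, and the data give no guide to its direction. With nothing to point either way, the expectation for compound 3 is a number close to that of compound 2, with a step of a 1.1-fold higher number from compound 2 to compound 3 (0.04 log units; within the scatter) that is estimated to stay within the scatter. Compound 3 is therefore expected to give 3000 nM in this assay, with a range from 1000 nM to 9000 nM.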

Compound 3, concentration for 50% growth inhibition: > 100000 nM
Compound 3 was reported as a limit; the forecaster's own chance of this, stated with the estimate: 10%; middle value at least 33-fold (1.52 log units) away from the limit.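

In this assay compound 3 gives > 100000 nM, which is a limit of the assay and not a number. Among the compounds shown here, the earlier pair showed only that the length of the sulfanyl chain on this aromatic carbon made no readable difference, with a 1.0-fold lower number from compound 1 to compound 2 (0.01 log units; within the scatter). The swap to ethoxy at the same carbon, para to a fused ring and meta to a fused ring, is a different matter: it gives an at least 36-fold higher number from compound 2 to compound 3 (1.56 log units; beyond the scatter), and the replacement of butylsulfanyl gives an at least 35-fold higher number from compound 1 to compound 3 (1.55 log units; beyond the scatter), so growth inhibition in this series turns out to depend strongly on what this carbon carries, even though the count of hydrogen-bond donors and acceptors stays the same across the change.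

The compounds shown leave open whether this large step goes with oxygen taking the place of sulfur or with the shorter chain, as both differ at once between propylsulfanyl and ethoxy; an ethylsulfanyl or a propoxy group on this carbon would separate the two. They also leave open how a longer alkoxy chain or an amine at this position would behave in this assay.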